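The source may hold more compounds than are shown below. What is called first, only, known or untested is meant among the compounds shown, and "the series" means these compounds.

Measured compounds in hand:
- compound 1 `C/C(CC(C)C)=N/Nc1nc(-c2cccc([N+](=O)[O-])c2)cs1`: 4410 nM
- compound 2 `CCCC/C(CC)=N\Nc1nc(-c2cccc([N+](=O)[O-])c2)cs1`: 6030 nM

In an assay on isolated protein for inhibition of Amine oxidase [flavin-containing] A (Homo sapiens), read by fluorescence, with a stated time of 20 min (a higher number here means a weaker inhibitor, a lower number a stronger inhibitor), compound 1 gives 4410 nM. In this assay compound 2 gives 6030 nM. Compound 1 holds the lower of the two numbers, but the gap to compound 2 lies within the usual scatter of repeated measurements, so the two cannot be told apart on the numbers alone.

The next compound in the series, compound 3 `C/C(=N/Nc1nc(-c2cccc([N+](=O)[O-])c2)cs1)C1CC1`, has not yet been measured in this assay. Relative to compound 1 the change is cyclopropyl in place of isobutyl on a carbon with a double bond to nitrogen. For the measured compounds named here, no pair of measured compounds differs in a single place, so there is no measured step of this kind to lean on. What the two measured numbers do show is that compound 1 and compound 2, which carry different groups on the carbon double-bonded to nitrogen, sit within the scatter of each other. On that basis the step of a 1.1-fold higher number from compound 1 to compound 3 (0.05 log units; within the scatter) is expected to stay within the scatter, with no clear direction. Compound 3 is estimated at 5000 nM, with a range from 2000 nM to 12000 nM.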

Compound 3, half-maximal inhibitory concentration: 2660 nM
Beside the measured number, compound 3's estimate is 1.9-fold (0.27 log units) above it; low and high end bracket the measured number.
By their numbers in this assay, from the lowest: compounds 3, 1 and 2 (each within the scatter of the next, the first and the last beyond it).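

The series now holds its first step between compounds that differ in one place: in this assay, cyclopropyl in place of isobutyl on a carbon with a double bond to nitrogen gives a 1.7-fold lower number from compound 1 to compound 3 (0.22 log units; within the scatter) and so cannot be told apart from no change. At this position, a three-membered non-aromatic ring of carbon only can therefore stand in for an open branched chain with no effect that the numbers can resolve, and the earlier pair, which differs in more than one place, could not show this for a single group. No measurement bears on the reason for this result.

From the compounds shown here alone, both groups in this step are uncharged, hold only carbon and carry no hydrogen-bond donors or acceptors, so it remains open whether an amine, a carboxylic acid or a phenyl ring at this carbon would move the number beyond the scatter. A single step within the scatter also leaves open how sensitive this position is to change at all, and the compounds shown say nothing on changes elsewhere on the shared core.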